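The compounds below may be only part of what the source reports. "The series", "measured", "known", "first", "only" and "open" are said of these compounds alone.

Compound 3, `NCc1ccc(-c2ccc(-c3nc4cc(C(F)(F)F)ccc4[nH]3)cc2)cc1`, in a functional assay for antagonist activity at Neuropeptides B/W receptor type 1 (Homo sapiens), read by cAMP accumulation (on this read-out higher numbers stand for weaker inhibition and lower numbers for stronger inhibition), gives 720 nM. That is the lower of the two numbers reported, but compound 1, `FC(F)(F)c1ccc2[nH]c(-c3ccccc3)nc2c1`, is close: in this assay compound 1 gives 1200 nM, and the step of a 1.7-fold lower number from compound 1 to compound 3 (0.22 log units; within the scatter) does not separate the two. Compound 2, `O=[N+]([O-])c1ccc2nc(-c3ccc(Cl)c(Cl)c3)[nH]c2c1`, gives only a limit in this assay, > 31600 nM. That one of the three results is such a limit, (the limit of > 31600 nM in this assay, at which 1 of the 3 values shown sits), is all that is known of it.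

Compound 4, `Cn1cc(-c2ccc(-c3nc4cc(C(F)(F)F)ccc4[nH]3)cc2)cn1`, differs from compound 3 in one place: 1-methyl-1H-pyrazol-4-yl in place of 4-(aminomethyl)phenyl on an aromatic carbon. Within the data shown here, the only measured step that touches this part of the structure is a 1.7-fold lower number from compound 1 to compound 3 (0.22 log units; within the scatter), which shows that adding the 4-(aminomethyl)phenyl group changed little. Swapping it for the 1-methyl-1H-pyrazol-4-yl group is therefore expected to move the number by little as well, in no clear direction, so the step of a 1.3-fold higher number from compound 3 to compound 4 (0.10 log units; within the scatter) is an estimate within the scatter. Compound 4 is accordingly expected to give about 900 nM in this assay, between 300 nM and 3000 nM.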

Compound 4, half-maximal inhibitory concentration: 1470 nM
For compound 4 the middle estimate is 1.6-fold (0.21 log units) below the measured one; low and high end bracket the measured number.
By their numbers in this assay, from the lowest: compounds 3, 1 and 4 (each within the scatter of the next, the first and the last beyond it). At a limit, above all of these: compound 2.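

Among these compounds, replacing the 4-(aminomethyl)phenyl group with 1-methyl-1H-pyrazol-4-yl gives the first step at this position that lies beyond the scatter in this assay, a 2.0-fold higher number from compound 3 to compound 4 (0.31 log units; beyond the scatter), although the step is modest. Against hydrogen at the same place, the 1-methyl-1H-pyrazol-4-yl group shows a 1.2-fold higher number from compound 1 to compound 4 (0.09 log units; within the scatter), so compound 1 cannot be separated from either compound 3 or compound 4, even though those two can just be separated from each other. Nothing measured here gives a reason for that small gap.

The compounds shown leave open whether the amine of compound 3 matters, which a plain phenyl group on this carbon would help to test. They also leave open whether a carboxylic acid or a longer chain carrying an amine would move the number further than these groups do.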